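This account rests on a few compounds, and the source may have more. Where it says the series, first, only, none or still open, it means among the compounds named here.

Compound 1, `Cc1nn2c(C(C)c3ccc(CC(C)C)cc3)nnc2s1`, gives 58% in a functional assay on the whole organism (strain Wistar albino) for inhibition, with Rattus norvegicus as the target, read by paw edema, with stated times of 30 min and 2 h, at a dose of 20 mg/kg by the oral route; a higher number here means more inhibition at the dose given (going by the name of the read-out), a lower number less inhibition.
Compound 2, `CCc1nn2c(C(C)c3ccc(CC(C)C)cc3)nnc2s1`, gives 45% in this assay.
Compound 3, `CCCc1nn2c(C(C)c3ccc(CC(C)C)cc3)nnc2s1`, gives 28% in this assay.

Compound 3 stands lowest of the three in this assay: the step of a number 17 percentage points lower from compound 2 to compound 3 (beyond the scatter) and the step of a number 30 percentage points lower from compound 1 to compound 3 (beyond the scatter) both set it apart from the others beyond the scatter. The three measured compounds share one core and differ only in the chain attached to it, and every step lengthens that chain: a number 13 percentage points lower from compound 1 to compound 2 (beyond the scatter), a number 30 percentage points lower from compound 1 to compound 3 (beyond the scatter) and a number 17 percentage points lower from compound 2 to compound 3 (beyond the scatter) all run downward, each one of modest size.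

Compound 4, `CC(C)Cc1ccc(C(C)c2nnc3sc(-c4ccc(Br)cc4)nn23)cc1`, makes a change of another kind: 4-bromophenyl in place of propyl on an aromatic carbon. Among the compounds with values here, none of the measured steps replaces a chain with an aromatic ring, so no step bears directly on this change, and the downward run of the chain steps can only hint that adding more at this place has so far lowered the read-out. The expectation for compound 4 in this assay is therefore uncertain and the range is kept wide. Compound 4 is expected to give 32%, between 8% and 60%, which means an expected step of a number 4 percentage points higher from compound 3 to compound 4 (within the scatter).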

Compound 4, a percentage reported as inhibition, in the whole organism at one dose (the size of the read-out at that dose, not a potency): 64%
The estimate for compound 4 lay 32 percentage points below the measured number; the whole stated range lies below it.
By their numbers in this assay, from the lowest: compound 3; then compound 2; then compounds 1 and 4 (each within the scatter of the next).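

At the aromatic carbon of the five-membered ring, a longer chain and a larger group do not have the same outcome in this assay: methyl, ethyl and propyl ran downward, but 4-bromophenyl, with more heavy atoms than propyl and a six-membered aromatic ring, breaks that run, as shown by a number 36 percentage points higher from compound 3 to compound 4 (beyond the scatter) and by a number 19 percentage points higher from compound 2 to compound 4 (beyond the scatter) in the comparison with ethyl. Against the smallest group of the set, the change gives a number 6 percentage points higher from compound 1 to compound 4 (within the scatter) and so offers no gain over methyl, which shows that this place accepts an aromatic ring while keeping the read-out at the level of the best chain compound. No measurement shown here explains why the ring behaves so differently from the chains.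

As far as these compounds go, it stays open whether the read-out follows the ring itself or the bromine on it, a question that plain phenyl and 4-chlorophenyl at the same place could address. Also unknown is how a bare hydrogen or a benzyl group, which puts a saturated carbon between the core and the ring, would compare with methyl and 4-bromophenyl.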